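This account rests on a few compounds, and the source may have more. Where it says the series, first, only, none or still open, it means among the compounds named here.

Series notes. Compound 1 `O[C@@H]1[C@@H](OCc2ccccc2)[C@H](OCc2ccccc2)[C@@H](COCc2ccccc2)O[C@H]1c1ccccc1` in a functional assay on HL-60 cells (Homo sapiens) for antiproliferative activity, read by MTT assay (on this read-out higher numbers stand for weaker inhibition and lower numbers for stronger inhibition), gives 26300 nM. Compound 2 `CCCC[C@@H]1O[C@H](COCc2ccccc2)[C@@H](OCc2ccccc2)[C@H](OCc2ccccc2)[C@H]1O` was reported in this assay as "not active" (no number reported), with no number given, so compound 2 stands at the weak end of what has been measured, and nothing can be said of its distance from compound 1 beyond that. Compound 3 `CCC[C@@H]1O[C@H](COCc2ccccc2)[C@@H](OCc2ccccc2)[C@H](OCc2ccccc2)[C@H]1O` differs from compound 2 by hydrogen in place of methyl on a saturated chain carbon, three bonds along the chain from a saturated ring carbon. For the measured compounds named here, no step between measured compounds is available to guide this change. With compound 2 not active and compound 1 at 26300 nM, no movement beyond the usual scatter in this assay is expected for compound 3. Compound 3 is expected to give about 40000 nM in this assay, estimated to lie between 10000 nM and 150000 nM.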

Compound 3, half-maximal inhibitory concentration: 11700 nM
Beside the measured number, compound 3's estimate is 3.4-fold (0.53 log units) above it; the measured number falls inside the stated range.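

In this assay, propyl in place of phenyl on a saturated ring carbon gives a 2.2-fold lower number from compound 1 to compound 3 (0.35 log units; beyond the scatter), so an aromatic ring at this position is not needed for a measurable value. Going from butyl in compound 2, reported as not active, to propyl in compound 3 at 11700 nM shows that a single chain carbon can decide whether a number is obtained at all, although the size of that step cannot be read without a number for compound 2. Nothing available accounts for either difference.

On these data alone, it remains open whether ethyl or methyl at this ring carbon would continue the trend from butyl to propyl or reverse it. Also open, as far as these compounds go, is how a chain ending in an amine or a carboxylic acid would read in this assay.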